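From propyl to butyl on compound 2

The source may hold more compounds than are shown below. What is called first, only, known or untested is meant among the compounds shown, and "the series" means these compounds.

Compound 1 `CCOC(=O)[C@@H](N)CCC(=O)NCCSC(=O)c1ccccc1` gives 8.85
Compound 2 `CCCOC(=O)[C@@H](N)CCC(=O)NCCSC(C)=O` gives 8.8

In a physicochemical assay for acid dissociation, using potentiometric titration, at pH 2, compound 2 gives 8.8 and stands within the scatter of compound 1 (at 8.85). Compound 3 `CCCCOC(=O)[C@@H](N)CCC(=O)NCCSC(C)=O` has not yet been measured. The change from compound 2 methyl in place of hydrogen on a saturated chain carbon, three bonds along the chain from an oxygen next to a carbonyl group is methyl in place of hydrogen on a saturated chain carbon, three bonds along the chain from an oxygen next to a carbonyl group, which also reads as propyl to butyl. Among the measured compounds shown here, no measured pair differs in one place only, so no direct guide exists. In this assay the expected step of no change at the digits printed from compound 2 to compound 3 (within the scatter) lies within the scatter. Compound 3 is estimated at 8.8 (range 8.55 to 9.05).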

Compound 3, acid dissociation constant: 8.69
Estimate against measurement, compound 3: 0.11 log units above; the range from low to high includes it.
By their numbers in this assay, from the lowest: compounds 3, 2 and 1 (each within the scatter of the next).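

In this assay, methyl in place of hydrogen on a saturated chain carbon, three bonds along the chain from an oxygen next to a carbonyl group, which also reads as propyl to butyl, gives a number 0.11 log units lower from compound 2 to compound 3 (within the scatter) as the first step read at this position. On this one pair, the two compounds cannot be told apart at this place. No measurement shown offers an explanation for this result.

The compounds shown leave open whether a longer chain or a carboxylic acid at this place would also stay within the scatter. Compound 1 differs from compound 2 in more than one place, so it cannot settle this.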